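Same Atoms, Rearranged Side Group: From Compound 2 to Compound 3

The compounds below may be only part of what the source reports. "The series", "measured", "known", "first", "only" and "open" are said of these compounds alone.

Measured so far (a functional assay on PC-3 cells (Homo sapiens) for inhibition, with a stated time of 72 h; on this read-out higher numbers stand for weaker inhibition and lower numbers for stronger inhibition):
- compound 1 `Cc1nc(-c2nc[nH]n2)ccc1-c1cnc2c(n1)N(CC1CCOCC1)C(=O)CN2` (82 nM)
- compound 2 `CO[C@H]1CC[C@H](N2C(=O)CNc3ncc(-c4ccc(-c5nc[nH]n5)nc4C)nc32)CC1` (38 nM)

Compound 2 holds the lower of these two numbers, so it is the stronger inhibitor so far. Compound 3 (`Cc1nc(-c2nc[nH]n2)ccc1-c1cnc2c(n1)N(CCC1CCOCC1)C(=O)CN2`) is not yet measured and carries a different side group: 2-(oxan-4-yl)ethyl in place of 4-methoxycyclohexyl on an amide-type nitrogen in a ring. Among the measured compounds shown here, one measured step bears on this change: a 2.2-fold lower number from compound 1 to compound 2 (0.33 log units; beyond the scatter), which put 4-methoxycyclohexyl in place of (oxan-4-yl)methyl. For the measured compounds named here, compound 3 returns to an oxane-bearing group, but no measured step covers its longer chain. A modest rise in this assay is therefore expected, of similar size. The expected change is a 2.1-fold higher number from compound 2 to compound 3 (0.32 log units; beyond the scatter) in this estimate. Compound 3 is estimated at 80 nM (range 30 nM to 200 nM).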

Compound 3, half-maximal inhibitory concentration: 34 nM
The estimate for compound 3 lay 2.4-fold (0.37 log units) above the measured number; measured number inside the range.
By their numbers in this assay, from the lowest: compounds 3 and 2 (each within the scatter of the next); then compound 1.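

In this assay, 2-(oxan-4-yl)ethyl in place of 4-methoxycyclohexyl gives a 1.1-fold lower number from compound 2 to compound 3 (0.05 log units; within the scatter), so this rearrangement of the same atoms, which also drops the two defined stereocentres, leaves the number within the scatter. Among the oxane-bearing groups, the chain matters: 2-(oxan-4-yl)ethyl in place of (oxan-4-yl)methyl gives a 2.4-fold lower number from compound 1 to compound 3 (0.38 log units; beyond the scatter), bringing this oxane-bearing group level with 4-methoxycyclohexyl. As far as these compounds go, whether a longer chain still, or an amine in place of the oxane ring oxygen, would hold this level remains open. No available evidence explains these numbers.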